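Methyl on the amide nitrogen of compound 2

The source may report more compounds than this note shows. Statements on the series, on what has been measured and on what is new or still open speak of the compounds shown alone.

- compound 1 `COC(=O)c1ccc(-c2nn(Cc3ccccc3)c3ccccc23)cc1` gives > 10000 nM
- compound 2 `NC(=O)c1ccc(-c2nn(Cc3ccccc3)c3ccccc23)cc1` gives > 10000 nM

In a functional assay on cells (Platelet, Homo sapiens) for inhibition (a lower number here means a stronger inhibitor, a higher number a weaker inhibitor), compound 2 has only a limit (> 10000 nM) and no number. Compound 1 likewise has only a limit (> 10000 nM) in this assay. The evidence so far is the limit of > 10000 nM in this assay, at which 2 of the 2 values shown sit, and nothing more.

Compound 3 `CNC(=O)c1ccc(-c2nn(Cc3ccccc3)c3ccccc23)cc1` follows from compound 2 through (methyl in place of hydrogen on an amide-type nitrogen), methyl in place of hydrogen on an amide-type nitrogen.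

Among the compounds with values here, the one measured step bearing on this is a step that the two limits leave unreadable from compound 1 to compound 2, amino in place of methoxy on a carbonyl carbon. Within the data shown here, with that step as the only guide, no change beyond the scatter is expected in this assay in either direction, and another limit is the likeliest reading. The expected step is a step that the limit leaves unreadable from compound 2 to compound 3, an estimate of low confidence. Compound 3 is estimated at 12000 nM (expected range 4000 nM to 40000 nM).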

Compound 3, half-maximal inhibitory concentration: > 10000 nM
Compound 3 ended at the assay's limit (the forecaster's own chance of this, stated with the estimate: 75%); the middle value is on the limit's open side.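

No step can be read among compound 1, compound 2 and compound 3 in this assay, since each has only a limit: the limit of > 10000 nM in this assay, at which 3 of the 3 values shown sit.

The compounds shown leave open how strongly any of the three inhibits, and whether methyl on the amide-type nitrogen changes that at all.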